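Fluoro substitution on a hydroxamate series against ASPC1 cells

A few compounds are considered here, and "the series" means these few. Any claim that something is new, unique, unknown or untested is made for them only; others in the source may bear on it.

Compound 1 `O=C(CCCCCCN1C(=O)/C(=N\O)c2ccccc21)NO` gives 1100 nM in a functional assay on ASPC1 cells (Homo sapiens) for antiproliferative activity, read by sulforhodamine B assay, with a stated time of 48 h; on this read-out lower numbers stand for stronger inhibition and higher numbers for weaker inhibition. Compound 2 `O=C(CCCCCCN1C(=O)/C(=N\O)c2cc(F)ccc21)NO` carries fluoro in place of hydrogen on an aromatic carbon on the core of compound 1; in this assay compound 2 gives 1720 nM, and the step is a 1.6-fold higher number from compound 1 to compound 2 (0.19 log units; within the scatter). Compound 3 `CO/N=C1/C(=O)N(CCCCCCC(=O)NO)c2ccccc21` keeps the side chain of compound 1 but has a different core; the difference between the two cores is not broken down here. Compound 3 gives 1220 nM in this assay, within the scatter of compound 1. Compound 4 `CO/N=C1/C(=O)N(CCCCCCC(=O)NO)c2ccc(F)cc21` is not yet measured and relates to compound 3 as compound 2 does to compound 1, with fluoro in place of hydrogen on an aromatic carbon, the same change at the same place. Compound 4 is expected to give about 1800 nM, between 1000 nM and 3400 nM. Among the compounds with values here, the expected step is a 1.5-fold higher number from compound 3 to compound 4 (0.17 log units; within the scatter), resting on the single earlier step of a 1.6-fold higher number from compound 1 to compound 2 (0.19 log units; within the scatter) for this change.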

Compound 4, half-maximal inhibitory concentration: 970 nM
Compound 4: the middle estimate sits 1.9-fold (0.27 log units) above what was measured; measured number below the stated range.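

Working from this assay, fluoro in place of hydrogen on an aromatic carbon gives a 1.3-fold lower number from compound 3 to compound 4 (0.10 log units; within the scatter). Set beside the earlier step, the change shows no difference between the two cores: the same change on two cores in this assay, a 1.6-fold higher number (0.19 log units; within the scatter) from compound 1 to compound 2 and a 1.3-fold lower number (0.10 log units; within the scatter) from compound 3 to compound 4, 2.0-fold (0.29 log units) apart, within the scatter of two such steps. So far it can be carried from one core to the other without a readable shift in this read-out, but two small steps show neither a real effect of fluoro on either core nor how the cores would compare for a change with a larger effect.

Still open, on these data alone, is whether a chloro or methoxy group on the same aromatic carbon would behave the same way on both cores. Also open, as far as these compounds go, is whether the result holds with a longer chain carrying the hydroxamic acid.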